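From Acetamido to Methanesulfonamido on the Shared Core

The source may hold more compounds than are shown below. What is called first, only, known or untested is meant among the compounds shown, and "the series" means these compounds.

In a functional assay for inhibition, with Homo sapiens as the target (a higher number here means a weaker inhibitor, a lower number a stronger inhibitor), compound 1 `CC(C)c1ccc2oc(NC(CC3CCCCC3)c3ccccc3)nc2c1` gives 6 nM, compound 2 `CCOC(=O)c1ccc2oc(NC(CC3CCCCC3)c3ccccc3)nc2c1` gives 45 nM and compound 3 `CC(=O)Nc1ccc2oc(NC(CC3CCCCC3)c3ccccc3)nc2c1` gives 78 nM. Compound 3 therefore stands level with compound 2 within the scatter and clearly above compound 1. Compound 4 `CS(=O)(=O)Nc1ccc2oc(NC(CC3CCCCC3)c3ccccc3)nc2c1` has methylsulfonyl in place of acetyl on a nitrogen on an aromatic ring. Going by the values given here, no measured step makes this exact change. Leaving isopropyl cost much, with a 7.5-fold higher number from compound 1 to compound 2 (0.88 log units; beyond the scatter) and a 13-fold higher number from compound 1 to compound 3 (1.11 log units; beyond the scatter), but the exchange among the other two groups stayed small, with a 1.7-fold higher number from compound 2 to compound 3 (0.24 log units; within the scatter). On that evidence, the expected change is a 1.3-fold higher number from compound 3 to compound 4 (0.11 log units; within the scatter), with no step beyond the scatter anticipated. Compound 4 is estimated at 100 nM, with an expected range of 35 nM to 300 nM.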

Compound 4, half-maximal inhibitory concentration: 160 nM
Estimate against measurement, compound 4: 1.6-fold (0.20 log units) below; the range from low to high includes it.
By their numbers in this assay, from the lowest: compound 1; then compounds 2 and 3 (each within the scatter of the next); then compound 4.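

In this assay, the groups that replaced isopropyl no longer all sit together: the change from acetamido to methanesulfonamido gives a 2.1-fold higher number from compound 3 to compound 4 (0.31 log units; beyond the scatter), whereas the earlier exchange among replacements stayed within the scatter. Compound 4 also separates from the ester, with a 3.6-fold higher number from compound 2 to compound 4 (0.55 log units; beyond the scatter). Its loss against isopropyl is the largest seen here, with a 27-fold higher number from compound 1 to compound 4 (1.43 log units; beyond the scatter), which makes compound 4 the weakest of the four.

Nothing at hand accounts for these steps. On these data alone, whether a tert-butyl group, a free amine or a carboxylic acid on this aromatic carbon would come closer to compound 1 remains open.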